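The source may hold more compounds than are shown below. What is called first, only, known or untested is meant among the compounds shown, and "the series" means these compounds.

Series on the shared core of compound 1 `CCCn1c(=O)c2nc(C(C)C)[nH]c2n(CCC)c1=O`. In an assay on cell membranes for binding affinity to adenosine receptor A1 (Cavia porcellus) (a higher number here means a weaker inhibitor, a lower number a stronger inhibitor), compound 1 gives 49 nM, compound 2 `CCCn1c(=O)c2nc(C(C)N)[nH]c2n(CCC)c1=O` gives 3000 nM and compound 3 `CCCC(CCC)c1nc2c(=O)n(CCC)c(=O)n(CCC)c2[nH]1` gives 78 nM. Compound 3 stands second highest of the three numbers; the steps of a 1.6-fold higher number from compound 1 to compound 3 (0.20 log units; within the scatter) and a 38-fold lower number from compound 2 to compound 3 (1.59 log units; beyond the scatter) place it. Compound 4 `CCCn1c(=O)c2nc(C(C3CC3)C3CC3)[nH]c2n(CCC)c1=O` is the next member: dicyclopropylmethyl in place of 1-propylbutyl on an aromatic carbon. The step that bears on this change is a 1.6-fold higher number from compound 1 to compound 3 (0.20 log units; within the scatter), an exchange of one branched chain for another on the same aromatic carbon. The step of a 61-fold higher number from compound 1 to compound 2 (1.79 log units; beyond the scatter) concerns an amino group and does not bear on it. For compound 4 in this assay a step of no more than the scatter is therefore expected, a 1.1-fold lower number from compound 3 to compound 4 (0.05 log units; within the scatter). The estimate for compound 4 is 70 nM, with a range of 25 nM to 200 nM.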

Compound 4, inhibition constant: 3 nM
Estimate against measurement, compound 4: 23-fold (1.37 log units) above; measured number outside the range, below it.
By their numbers in this assay, from the lowest: compound 4; then compounds 1 and 3 (each within the scatter of the next); then compound 2.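

At the aromatic carbon between two ring nitrogen atoms, dicyclopropylmethyl in place of 1-propylbutyl keeps the heavy-atom count and brings in two three-membered rings, giving a 26-fold lower number from compound 3 to compound 4 (1.41 log units; beyond the scatter) in this assay. Dicyclopropylmethyl also separates from the other groups, with a 16-fold lower number from compound 1 to compound 4 (1.21 log units; beyond the scatter) and a 1000-fold lower number from compound 2 to compound 4 (3.00 log units; beyond the scatter), so branched groups at this position are not interchangeable, although isopropyl and 1-propylbutyl lie within the scatter of each other. Nothing available explains the difference.

Open, as far as these compounds go, is whether one ring gives the same shift, as a single cyclopropyl or a cyclopropylmethyl group at this position would show.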